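One side chain exchanged on a shared core

The compounds below may be only part of what the source reports. "The series", "measured", "known", "first", "only" and "open" are said of these compounds alone.

Measured in a functional assay on A549 cells (Homo sapiens) for cytotoxicity, read by MTT assay, with a stated time of 72 h; on this read-out lower numbers stand for stronger inhibition and higher numbers for weaker inhibition:
- Compound 1 `O=C1c2c[n+]([O-])c3ccccc3c2C(=O)c2c1c1ccccc1n2Cc1cn(CC(O)CO)nn1` gives 880 nM
- Compound 2 `O=C1c2c[n+]([O-])c3ccccc3c2C(=O)c2c1c1ccccc1n2CCN1CCCC1` gives 410 nM
- Compound 3 `CCCCN1CCN(CCCCn2c3c(c4ccccc42)C(=O)c2c[n+]([O-])c4ccccc4c2C3=O)CC1` gives 550 nM

Compound 3 at 550 nM lies within the usual scatter of both compound 2 and compound 1, so it cannot be ranked against either. Compound 4 `O=C1c2c[n+]([O-])c3ccccc3c2C(=O)c2c1c1ccccc1n2CCN1CCCCC1` differs from compound 3 by a single change, (piperidin-1-yl in place of 2-(4-butylpiperazin-1-yl)ethyl on a saturated chain carbon, two bonds along the chain from an aromatic nitrogen), with piperidin-1-yl in place of 2-(4-butylpiperazin-1-yl)ethyl on a saturated chain carbon, two bonds along the chain from an aromatic nitrogen. The closest evidence is a 1.3-fold higher number from compound 2 to compound 3 (0.13 log units; within the scatter), a step at that same place and within the scatter. The other measured step, a 2.1-fold lower number from compound 1 to compound 2 (0.33 log units; beyond the scatter), is modest and involves a different exchange, so it bears on this change only loosely. No step beyond the scatter is therefore expected in this assay. The expected step is a 1.3-fold lower number from compound 3 to compound 4 (0.11 log units; within the scatter) and would stay within the scatter. For compound 4 the estimated value is 430 nM, with an expected range from 210 nM to 900 nM.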

Compound 4, half-maximal inhibitory concentration: 1080 nM
Estimate against measurement, compound 4: 2.5-fold (0.40 log units) below; measured number above the stated range.
By their numbers in this assay, from the lowest: compounds 2, 3, 1 and 4 (each within the scatter of the next, the first and the last beyond it).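

In this assay this position, on a saturated chain carbon two bonds along the chain from an aromatic nitrogen, gives its first step beyond the scatter: piperidin-1-yl in place of pyrrolidin-1-yl produces a 2.6-fold higher number from compound 2 to compound 4 (0.42 log units; beyond the scatter) and so separates two closely matched amines. By contrast, replacing 2-(4-butylpiperazin-1-yl)ethyl, with 12 heavy atoms, by piperidin-1-yl, with 6, gives a 2.0-fold higher number from compound 3 to compound 4 (0.29 log units; within the scatter) and stays within the scatter, as does the exchange at the other attachment, which gives a 1.2-fold higher number from compound 1 to compound 4 (0.09 log units; within the scatter) and leaves compound 4 unranked against compound 3 or compound 1. No measurement on hand explains why the piperidin-1-yl and pyrrolidin-1-yl groups differ here.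

The compounds shown leave open whether a morpholin-4-yl group or an open-chain diethylamino group at this place would fall nearer compound 2 or compound 4. They also leave open how a longer chain carrying the piperidin-1-yl group would read.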